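Adding a methoxycarbonyl to an indole amide

The compounds below may be only part of what the source reports. "The series", "measured", "known", "first", "only" and "open" are said of these compounds alone.

Going by the values given here, compound 2 `CN(C)C(=O)c1cn(C)c2ccccc12` is one of two compounds measured so far in an ADME assay for permeability, using PAMPA, at pH 7.4; on this read-out higher numbers stand for higher permeability and lower numbers for lower permeability; compound 2 gives 6.7 10^-6 cm/s, the higher of the two numbers. Compound 1 `O=C(NCc1cccnc1)c1ccc2ccc(C(=O)c3ccccc3)c-2cc1` gives 2.4 10^-6 cm/s in this assay, and the gap between compound 1 and compound 2 lies beyond the usual scatter. Compound 3 `COC(=O)c1ccc2c(C(=O)N(C)C)cn(C)c2c1` differs from compound 2 in one place: methoxycarbonyl in place of hydrogen on an aromatic carbon. Among the compounds with values here, no measured pair shows the effect of this change, so compound 3 is expected to sit close to compound 2, with the step of a 1.0-fold higher number from compound 2 to compound 3 (0.02 log units; within the scatter) expected to stay within the scatter. Compound 3 is estimated at 7 10^-6 cm/s, with a range from 3.5 10^-6 cm/s to 14 10^-6 cm/s.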

Compound 3, apparent permeability: 4.2 10^-6 cm/s
Compound 3: middle estimate off by 1.7-fold (0.22 log units), on the high side, within the range that was stated.
By their numbers in this assay, from the lowest: compounds 1, 3 and 2 (each within the scatter of the next, the first and the last beyond it).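

In this assay, going by these compounds alone, methoxycarbonyl in place of hydrogen on this aromatic carbon gives a 1.6-fold lower number from compound 2 to compound 3 (0.20 log units; within the scatter), so the first measured change on the shared core leaves the read-out within the scatter. This single pair shows that this position, on the six-membered aromatic ring of carbon only, carries methoxycarbonyl without a step beyond the scatter. Nothing available accounts for the size of this step. The compounds shown leave open whether a carboxylic acid or an amine on the same aromatic carbon would also stay within the scatter, and whether methoxycarbonyl on another carbon of that ring would do so.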